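This account rests on a few compounds, and the source may have more. Where it says the series, first, only, none or still open, it means among the compounds named here.

Measured so far in an ADME assay on L6 cells (Rattus norvegicus) for inhibition, read by resazurin assay, with a stated time of 72 h; a higher number here means a weaker inhibitor, a lower number a stronger inhibitor:
compound 1 `CS(=O)(=O)C[C@H]1O[C@@H](n2cnc3c(N)nc(F)nc32)[C@H](O)[C@@H]1O`: 5000 nM
compound 2 `CS(=O)(=O)C[C@H]1O[C@@H](n2cnc3c(N)nc(Cl)nc32)[C@H](O)[C@@H]1O`: 156000 nM
compound 3 `CC(=O)O[C@@H]1[C@H](OC(C)=O)[C@@H](CN2C(=O)c3ccccc3C2=O)O[C@H]1n1cnc2c(N)nc(F)nc21`: 129000 nM

Compound 1 holds the lowest of the three numbers. Compound 4 `CC(=O)NC[C@H]1O[C@@H](n2cnc3c(N)nc(F)nc32)[C@H](O)[C@@H]1O` has not yet been measured in this assay. It departs from compound 1 by one change: acetamido in place of methylsulfonyl on a saturated chain carbon bound to a saturated ring carbon. In short, acetamido stands in place of methylsulfonyl on a saturated chain carbon bound to a saturated ring carbon.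

Among the measured compounds shown here, no measured step touches this place. For the measured compounds named here, the only single-place step is a 31-fold higher number from compound 1 to compound 2 (1.49 log units; beyond the scatter), with chloro in place of fluoro on an aromatic carbon. Going by the values given here, that step is large, but it lies elsewhere in the structure, so it shows only that one change can move values far. Compound 1 differs from compound 3 in more than one place, so compound 3 at 129000 nM isolates no single change.

A moderate step toward a higher number is expected because compound 1 at 5000 nM is the lowest of the three, although its size is poorly constrained. The estimated step is a 4.0-fold higher number from compound 1 to compound 4 (0.60 log units; beyond the scatter). For compound 4 the expected value is 20000 nM, with an estimated range from 5000 nM to 90000 nM.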

Compound 4, half-maximal inhibitory concentration: 182000 nM
For compound 4 the middle estimate is 9.1-fold (0.96 log units) below the measured one, and the stated range ends below it.
By their numbers in this assay, from the lowest: compound 1; then compounds 3, 2 and 4 (each within the scatter of the next).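

Acetamido in place of methylsulfonyl on a saturated chain carbon bound to a saturated ring carbon gives a 36-fold higher number from compound 1 to compound 4 (1.56 log units; beyond the scatter) in this assay and provides the first single-place reading at this position. The earlier step concerned only the aromatic carbon, so the position bearing methylsulfonyl is now also shown to be able to move the value far while the rest of compound 1 stays unchanged. The two groups match in heavy-atom count but differ in their atoms, double bonds, hydrogen-bond donors and hydrogen-bond acceptors, and no accompanying measurement indicates which of these differences matters.

Going by these compounds, with only methylsulfonyl and acetamido compared here, it remains open whether compound 1 reflects something particular to methylsulfonyl or whether other groups at this position, such as an amine, a carboxylic acid, a methylsulfonamide or a longer alkylsulfonyl chain, would give similarly low numbers. It also remains open whether the step seen with fluoro on the aromatic carbon would have the same size with chloro there, since no pair shown tests the two changes together.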